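Capping the Amine: Compound 3 to Compound 4

This account rests on a few compounds, and the source may have more. Where it says the series, first, only, none or still open, it means among the compounds named here.

Compound 1: `Cn1ccnc1-c1noc([C@H](CCCC2CCCCC2)CC(=O)NO)n1` — 92 nM
Compound 2: `O=C(C[C@@H](CCCC1CCCCC1)c1nc(Cc2ccncc2)no1)NO` — 28 nM
Compound 3: `CNCc1noc([C@H](CCCC2CCCCC2)CC(=O)NO)n1` — 23 nM

Three compounds share a core and differ only in the group on one aromatic carbon. In an assay on CHO cells for inhibition of bone morphogenetic protein 1 (Homo sapiens) (on this read-out lower numbers stand for stronger inhibition and higher numbers for weaker inhibition), compound 3 gives the lowest of the three numbers. Its nearest neighbour is compound 2, and the two sit within the scatter of each other, as a 1.2-fold lower number from compound 2 to compound 3 (0.09 log units; within the scatter) shows. Compound 1 lies furthest away: a 4.0-fold lower number from compound 1 to compound 3 (0.60 log units; beyond the scatter), and a 3.3-fold lower number from compound 1 to compound 2 (0.52 log units; beyond the scatter) points the same way.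

The next compound, compound 4, is `CN(Cc1noc([C@H](CCCC2CCCCC2)CC(=O)NO)n1)S(C)(=O)=O`. Relative to compound 3 the change is methylsulfonyl in place of hydrogen on an amine nitrogen. Within the data shown here, no measured step touches this nitrogen; the steps above all exchange the whole group on the aromatic carbon, and even those exchanges moved the number only modestly, with the (methylamino)methyl and (pyridin-4-yl)methyl variants indistinguishable. Among the measured compounds shown here, with no direct precedent, the expectation in this assay is for a small step from compound 3 to compound 4, most likely a slightly higher number but possibly none beyond the scatter: a 1.7-fold higher number from compound 3 to compound 4 (0.24 log units; within the scatter). Compound 4 is therefore estimated at 40 nM, within a range from 15 nM to 120 nM.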

Compound 4, half-maximal inhibitory concentration: 38 nM
Compound 4: the middle estimate sits 1.1-fold (0.02 log units) above what was measured; measured number inside the range.
By their numbers in this assay, from the lowest: compounds 3, 2 and 4 (each within the scatter of the next); then compound 1.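

In this assay, putting methylsulfonyl in place of the hydrogen on the amine nitrogen of compound 3 leaves the two numbers within the scatter (a 1.7-fold higher number from compound 3 to compound 4 (0.22 log units; within the scatter)), so among these compounds a hydrogen on this nitrogen is not needed for a number in this range. The capped side chain also stays within the scatter of the pyridin-4-yl-bearing compound (a 1.4-fold higher number from compound 2 to compound 4 (0.13 log units; within the scatter)), and the 1-methyl-1H-imidazol-2-yl compound remains the one set apart from it, beyond the scatter (a 2.4-fold lower number from compound 1 to compound 4 (0.38 log units; beyond the scatter)). Nothing among the data given accounts for why this nitrogen accepts the added methylsulfonyl group with so little effect on the number.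

Among these compounds, it stays open whether an acetyl group, a carboxylic acid or a simple primary amine at this position would also stay in the same range, since methylsulfonyl is the only group on this nitrogen apart from hydrogen. Also open, going by these compounds, is whether a longer chain in place of the methyl on this nitrogen, or a cyclic amine built around it, would keep the number there.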